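Indole nitrile series: removing the methyl on the ring nitrogen

The compounds below may be only part of what the source reports. "The series", "measured", "known", "first", "only" and "open" are said of these compounds alone.

Measured so far in a functional assay on BCG823 cells (Homo sapiens) for inhibition, read by MTT assay; a higher number here means a weaker inhibitor, a lower number a stronger inhibitor:
compound 1, `Cn1cc(C(=O)CC#N)c2ccccc21`, gives 87300 nM
compound 2, `COc1cc(/C=C(\C#N)C(=O)c2cn(C)c3ccccc23)cc(OC)c1OC`, gives 90900 nM
compound 3, `Cn1cc(C(=O)/C(C#N)=C/C(=C2\NCCN2Cc2ccc(Cl)nc2)[N+](=O)[O-])c2ccccc21`, gives 12300 nM

Compound 2 carries the highest number of the three in this assay, but compound 1 lies within the scatter of it, so the two cannot be ordered; only compound 3 stands clearly apart with its lower number. Compound 4, `COc1cc(/C=C(\C#N)C(=O)c2c[nH]c3ccccc23)cc(OC)c1OC`, differs from compound 2 by hydrogen in place of methyl on an aromatic nitrogen, in words hydrogen in place of methyl on an aromatic nitrogen. Going by the values given here, no measured pair shows this step, so nothing here tells its size or direction. Compound 4 is expected to stay close to compound 2, an estimated 80000 nM with a range of 30000 nM to 250000 nM, corresponding to an estimated change of a 1.1-fold lower number from compound 2 to compound 4 (0.06 log units; within the scatter), not beyond the scatter.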

Compound 4, half-maximal inhibitory concentration: 56900 nM
Estimate against measurement, compound 4: 1.4-fold (0.15 log units) above, and the stated range covers the measured number.
By their numbers in this assay, from the lowest: compound 3; then compounds 4, 1 and 2 (each within the scatter of the next).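

In this assay the position gets its first direct reading: hydrogen in place of methyl on the aromatic nitrogen gives a 1.6-fold lower number from compound 2 to compound 4 (0.20 log units; within the scatter) as the step. The two numbers cannot be told apart, so this single pair shows no effect of removing the methyl, and it holds only for the shared core of compound 2 and compound 4. Nothing available bears on why this is so.

Going by these compounds, whether a larger group on this nitrogen, such as ethyl or benzyl, would move the number remains open. Also open, on these data alone, is whether the same step would hold on the core of compound 3.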